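A few compounds are considered here, and "the series" means these few. Any claim that something is new, unique, unknown or untested is made for them only; others in the source may bear on it.

Measured compounds in a physicochemical assay for solubility, read by HPLC, in phosphate buffer, with a stated time of 24 h, at pH 7.4, tested at 100 uM; on this read-out lower numbers stand for lower solubility and higher numbers for higher solubility:
compound 1, `CN(C)c1ccc(Nc2c(NCCCCCC(=O)NO)c(=O)c2=O)cc1`, gives 12000000 nM
compound 2, `CC(CCCCC(=O)NO)Nc1c(Nc2ccc(C(F)(F)F)cc2)c(=O)c1=O`, gives 30000000 nM
compound 3, `C[C@H](CCCCC(=O)NO)Nc1c(Nc2ccc(N(C)C)cc2)c(=O)c1=O`, gives 80000000 nM

Compound 3 differs from compound 1 by methyl in place of hydrogen on a saturated chain carbon bound to a nitrogen on an aromatic ring and a saturated chain carbon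

In this assay this change gave a 6.7-fold higher number from compound 1 to compound 3 (0.82 log units; beyond the scatter), a gain beyond the scatter. Compound 2 stands between them: its value is higher than that of compound 1 and lower than that of compound 3, both gaps beyond the scatter. How the core of compound 2 differs from that of compound 1 is not broken down here.

The unmeasured compound 4, `CC(C)(CCCCC(=O)NO)Nc1c(Nc2ccc(C(F)(F)F)cc2)c(=O)c1=O`, differs from compound 2 by methyl in place of hydrogen on a saturated chain carbon bound to a nitrogen on an aromatic ring and two saturated chain carbons

This is the same kind of change as from compound 1 to compound 3, but the place is not identical: in compound 4 the carbon carries a nitrogen on an aromatic ring and two saturated chain carbons, whereas in compound 3 it carries a nitrogen on an aromatic ring and one saturated chain carbon. Going by the values given here, only one such step has been measured, so the expectation rests on it alone. In this assay, among the compounds with values here, a step of about a 2.0-fold higher number from compound 2 to compound 4 (0.30 log units; within the scatter) is expected from compound 2 to compound 4, somewhat smaller than the measured one because a 6.7-fold higher number from compound 1 to compound 3 (0.82 log units; beyond the scatter) is the only guide and the surroundings differ. Compound 4 is thus estimated at 60000000 nM, in the range 20000000 nM to 150000000 nM.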

Compound 4, solubility: 36000000 nM
Compound 4: the middle estimate sits 1.7-fold (0.22 log units) above what was measured; measured number inside the range.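

In this assay, methyl in place of hydrogen gave a 6.7-fold higher number from compound 1 to compound 3 (0.82 log units; beyond the scatter) on the core of compound 1, while the same kind of change gave a 1.2-fold higher number from compound 2 to compound 4 (0.08 log units; within the scatter) on the core of compound 2, so the step beyond the scatter did not reappear on the second core. This shows that the first step cannot be carried over unchanged, but it does not separate the effect of the core from that of the place, since the carbon carries one saturated chain carbon in compound 3 and two in compound 4, and each case rests on a single pair. Nothing at hand accounts for the difference between the two steps.

Still open, on these data alone, is whether a second methyl on that carbon would behave the same way on the core of compound 1. Also open, as far as these compounds go, is whether the step would hold with an amine or a carboxylic acid in place of the trifluoromethyl, or with a longer chain in place of the methyl.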